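Compound 3 at the assay limit, and a halogen swap

The source may report more compounds than this note shows. Statements on the series, on what has been measured and on what is new or still open speak of the compounds shown alone.

Measured in a functional assay on RAW264.7 cells (Mus musculus) for inhibition, read by Griess assay, with a stated time of 20 h (a higher number here means a weaker inhibitor, a lower number a stronger inhibitor), each value a limit:
Compound 1 `CCCNC(=O)c1cc(-n2cc(-c3cc(F)cc(F)c3)nn2)ccc1O`: > 20000 nM
Compound 2 `CC(C)CCc1cn(-c2ccc(O)c(C(=O)N3CCCCC3)c2)nn1`: > 20000 nM
Compound 3 `O=C(c1cc(-n2cc(-c3cccc(Cl)c3)nn2)ccc1O)N1CCCCC1`: > 20000 nM

Compound 3 gives > 20000 nM, which is a limit and not a number. That is where it stands, with nothing shown on either side of it, since the evidence so far is the limit of > 20000 nM in this assay, at which 3 of the 3 values shown sit.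

The next compound is compound 4 `O=C(c1cc(-n2cc(-c3cc(F)cc(F)c3)nn2)ccc1O)N1CCCCC1`, and the change is 3,5-difluorophenyl in place of 3-chlorophenyl on an aromatic carbon. Within the data shown here, the only measured step at this place is a step that the two limits leave unreadable from compound 2 to compound 3, so it offers no size to carry over. Compound 1 carries the same 3,5-difluorophenyl on a different amide. Compound 1 gives > 20000 nM, again a limit.

On these compounds, no step beyond the scatter is expected in this assay, in either direction, and a reading at the limit is the likeliest outcome. The estimate amounts to an expected a number no higher from compound 3 to compound 4 (the limit leaves the size open). Compound 4 is estimated at 20000 nM, with an expected range from 8000 nM to 40000 nM.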

Compound 4, half-maximal inhibitory concentration: > 20000 nM
Compound 4 ended at the assay's limit; the forecaster's own chance of this, stated with the estimate: 75%; the middle value lies on the limit itself.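

Among these compounds, compound 4 gives > 20000 nM, a limit and not a number, so no step from compound 1, compound 2 or compound 3 to compound 4 can be read. The compounds shown leave open how strongly any of them inhibits, and whether changing either the aryl group or the amide alters that.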